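This account rests on a few compounds, and the source may have more. Where it says the series, first, only, none or still open, it means among the compounds named here.

Series notes. In an ADME assay on HT-29 cells (Homo sapiens) for inhibition, read by MTT assay, with a stated time of 72 h (a higher number here means a weaker inhibitor, a lower number a stronger inhibitor), compound 1 `CN(C)C/C=C/C(=O)Nc1cccc(Nc2nc(N/N=C/c3ccccc3F)ncc2Cl)c1` gives 3660 nM. Compound 2 `CN(C)C/C=C/C(=O)Nc1cccc(Nc2nc(N/N=C/c3c[nH]c4ccccc34)ncc2Cl)c1` gives in this assay 9680 nM, and compound 3 `C/C(=N\Nc1ncc(Cl)c(Nc2cccc(NC(=O)/C=C/CN(C)C)c2)n1)c1ccc(F)cc1` gives in this assay 10200 nM. For the measured compounds named here, compound 3 thus holds the highest of the three numbers in this assay, though its value and that of compound 2 lie within the scatter of each other, as a 1.1-fold higher number from compound 2 to compound 3 (0.02 log units; within the scatter) shows; only the step of a 2.8-fold higher number from compound 1 to compound 3 (0.45 log units; beyond the scatter) lies beyond it.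

Compound 4 `COc1cccc(/C(C)=N/Nc2ncc(Cl)c(Nc3cccc(NC(=O)/C=C/CN(C)C)c3)n2)c1` differs from compound 3 in one place: 3-methoxyphenyl in place of 4-fluorophenyl on a carbon with a double bond to nitrogen. The measured steps that bear on this are those that alter the aryl group on the same carbon. The step of a 2.6-fold higher number from compound 1 to compound 2 (0.42 log units; beyond the scatter) moved the number modestly upward, and a 2.8-fold higher number from compound 1 to compound 3 (0.45 log units; beyond the scatter) did likewise, while a 1.1-fold higher number from compound 2 to compound 3 (0.02 log units; within the scatter) stayed within the scatter. Going by the values given here, no measured pair exchanges a fluorine for a methoxy group on this ring, so the direction of this particular change is not established. Since aryl changes here have produced at most modest shifts, for compound 4 in this assay a step of a 1.0-fold lower number from compound 3 to compound 4 (0.01 log units; within the scatter) is expected, within the scatter. Compound 4 is therefore estimated at 10000 nM in this assay, with a range from 4000 nM to 25000 nM.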

Compound 4, half-maximal inhibitory concentration: 3870 nM
Compound 4: the middle estimate sits 2.6-fold (0.41 log units) above what was measured, outside the stated range (below it).
By their numbers in this assay, from the lowest: compounds 1 and 4 (each within the scatter of the next); then compounds 2 and 3 (each within the scatter of the next).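

In this assay the aryl group on the carbon with a double bond to nitrogen moves the number by itself, with the rest of the structure held fixed: there is a 2.6-fold lower number from compound 3 to compound 4 (0.42 log units; beyond the scatter) when 3-methoxyphenyl replaces 4-fluorophenyl. Compound 4 also separates from the indole-bearing compound, with a 2.5-fold lower number from compound 2 to compound 4 (0.40 log units; beyond the scatter) on record, while a 1.1-fold higher number from compound 1 to compound 4 (0.02 log units; within the scatter) leaves it level with the 2-fluorophenyl hydrazone despite the added saturated chain carbon. Nothing available bears on the reason for this shift.

Going by these compounds, what 3-fluorophenyl or 4-methoxyphenyl gives on this carbon remains open, so the identity of the substituent and its ring position cannot yet be told apart. Also open, on these data alone, is how an amine or a carboxylic acid on this ring would behave.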